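Chloro on the phenyl of compound 1: solubility outlook

The source may report more compounds than this note shows. Statements on the series, on what has been measured and on what is new or still open speak of the compounds shown alone.

The account begins with compound 1 `CCOC(=O)c1c(-c2ccccc2)[nH]c2cc(OC)ccc2c1=O`, which in a physicochemical assay for solubility, in phosphate buffer, at pH 7.4 (a higher number here means a more soluble compound, a lower number a less soluble compound), gives > 100000 nM; this is a limit of the assay and not a number. Compound 3 `CCOC(=O)c1c(-c2cccc(Cl)c2)[nH]c2cccc(OC)c2c1=O` in this assay also gives > 100000 nM, again a limit rather than a number. Compound 2 `CCOC(=O)c1c(-c2ccc(C(C)(C)C)cc2)[nH]c2cccc(OC)c2c1=O` stands apart, giving 1000 nM in this assay. Thus compound 1 sits at the point noted as the limit of > 100000 nM in this assay, at which 2 of the 3 values shown sit, with only a range known for it, and no measured pair differing in one place is available to size a step.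

The unmeasured compound 4 `CCOC(=O)c1c(-c2cccc(Cl)c2)[nH]c2cc(OC)ccc2c1=O` differs from compound 1 by chloro in place of hydrogen on an aromatic carbon. It thereby carries the same 3-chlorophenyl group as compound 3, whose value in this assay remains at the limit, while the lower value of compound 2 comes with a tert-butyl group instead.

Given that compound 3 with its chloro group stays at the limit, the author expects the step of an at least 1.2-fold lower number from compound 1 to compound 4 (0.09 log units; that floor lies within the scatter) to be small, within the scatter or no more than a modest fall. The estimate for compound 4 in this assay is 80000 nM, with a range from 20000 nM to 150000 nM, and a fair chance that only a limit is reported again.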

Compound 4, solubility: 58000 nM
For compound 4 the middle estimate is 1.4-fold (0.14 log units) above the measured one; measured number inside the range.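

Among these compounds, the change of phenyl to 3-chlorophenyl gives the first step that can be sized at this position, an at least 1.7-fold lower number from compound 1 to compound 4 (0.23 log units; that floor lies within the scatter), read in this assay. On the core of compound 1, compound 4 gives 58000 nM, so this place on the phenyl ring now has a reading that is a number and not a limit, and later changes at the same place can be set against it. The step itself remains a floor and not a full size, because compound 1 stands at a limit of the assay and not at a number: the limit of > 100000 nM in this assay, at which 2 of the 4 values shown sit.

The compounds shown leave open how a carboxylic acid, an amine or a fluoro group in place of the chloro group would read in this assay, and whether any of these would differ from compound 4 by more than the scatter. They also leave open whether chloro at another place on the phenyl ring would give a similar reading, and how far the true distance between the pair reaches, which only a number for compound 1 could settle.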